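The source may hold more compounds than are shown below. What is called first, only, known or untested is meant among the compounds shown, and "the series" means these compounds.

Measured in a functional assay on NALM-6 cells (Homo sapiens) for cytotoxicity, with a stated time of 72 h; on this read-out lower numbers stand for an effect already at smaller amounts and higher numbers for an effect only at larger amounts of compound:
- Compound 1 `C=C[C@@](C)(/C=C/c1ccc(OCc2ccccc2)cc1)CCC=C(C)C`: > 43400 nM, a limit
- Compound 2 `C=C[C@@](C)(/C=C/c1ccc(OS(=O)(=O)C(F)(F)F)cc1)CCC=C(C)C`: > 43400 nM, a limit
- Compound 3 `C=C[C@@](C)(/C=C/c1ccc(O)cc1)CCC=O`: > 43400 nM, a limit

Compound 3 thus offers no number, only (the limit of > 43400 nM in this assay, at which 3 of the 3 values shown sit). Compound 4 `C=C[C@@](C)(/C=C/c1ccc(O)cc1)CCCO` carries hydroxymethyl in place of formyl on a saturated chain carbon, three bonds along the chain from two double-bonded chain carbons. For the measured compounds named here, the only measured step, a step that the two limits leave unreadable from compound 1 to compound 2, concerns a different group and gives no size to carry over. Since compound 3 stands at > 43400 nM, a limit, nothing points to a gain, and no change beyond the scatter is expected. The expected step is a step that the limit leaves unreadable from compound 3 to compound 4. For compound 4 the estimated value is 45000 nM, with an expected range of 25000 nM to 90000 nM.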

Compound 4, half-maximal effective concentration: > 43400 nM
Compound 4 gave a limit, no number; the forecaster's own chance of this, stated with the estimate: 85%; the middle value does not contradict the limit.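

No step can be read from compound 3 to compound 4, as each gives only a limit in this assay: the limit of > 43400 nM in this assay, at which 4 of the 4 values shown sit.

The compounds shown leave open whether hydroxymethyl in place of formyl changes the effect at all, and what a measurable value would look like.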